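This account rests on a few compounds, and the source may have more. Where it says the series, first, only, none or still open, it means among the compounds named here.

Measured in a functional assay on CHO cells for antagonist activity at adenosine receptor A2b (Homo sapiens), read by 33P incorporation, with a stated time of 20 min, in the presence of a further agent that is not named here; a higher number here means a weaker inhibitor, a lower number a stronger inhibitor:
compound 1 `Cn1cc2c(Cl)nc(NC(=O)c3ccccc3)nc2n1`: > 20000 nM
compound 2 `CC(C)n1cc2c(Cl)nc(NC(=O)c3ccccc3)nc2n1`: > 20000 nM
compound 3 `Cn1cc2c(Cl)nc(N)nc2n1`: > 20000 nM

Each of these three values is a limit of this assay and not a number. All three sit at the limit of > 20000 nM in this assay, at which 3 of the 3 values shown sit. Compound 1 and compound 2 differ by isopropyl in place of methyl on an aromatic nitrogen; the step that the two limits leave unreadable from compound 1 to compound 2 is left unreadable by the two limits. The core of compound 3 differs from the core of compound 1 in more than one place, and that difference is not broken down here.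

Compound 4 `CC(C)n1cc2c(Cl)nc(N)nc2n1` is not yet measured. It differs from compound 3 by isopropyl in place of methyl on an aromatic nitrogen, the same change as between compound 1 and compound 2. For compound 4 a step that the limit leaves unreadable from compound 3 to compound 4 is expected in this assay. This rests on compound 3 showing only the limit > 20000 nM. It also rests on the matching change giving a step that the two limits leave unreadable from compound 1 to compound 2. Compound 4 is therefore estimated at 30000 nM, most likely again a limit.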

Compound 4, inhibition constant: > 10000 nM
Compound 4 was reported as a limit; the forecaster's own chance of this, stated with the estimate: 90%; the middle value does not contradict the limit.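

In this assay compound 4 gives > 10000 nM, which is a limit. Compound 3 gives > 20000 nM, also a limit, so the step between compound 3 and compound 4 cannot be read. The compounds shown leave open whether any member of this series has a measurable inhibition constant.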